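This account rests on a few compounds, and the source may have more. Where it says the series, first, only, none or still open, it means among the compounds named here.

In an assay on HEK293 cells for displacement of a labelled ligand from growth hormone secretagogue receptor type 1 (Homo sapiens), with a stated time of 60 min (a lower number here means a stronger inhibitor, a higher number a weaker inhibitor), compound 2 `CN1CCCN(CCCS(=O)(=O)c2ccc3nc(NC(=O)NC(=O)c4ccccc4Cl)sc3c2)CC1` gives 4.2 nM, the highest number among the three measured compounds. Compound 1 `CN1CCC(S(=O)(=O)c2ccc3nc(NC(=O)NC(=O)c4cc(N5CCCC5)c(C#N)cc4Cl)sc3c2)CC1` gives 0.4 nM, and compound 3 `CN1CCN(CCCS(=O)(=O)c2ccc3nc(NC(=O)NC(=O)c4cc(C5CC5)ccc4Cl)sc3c2)CC1` gives 0.33 nM; both of these numbers lie far below that of compound 2, and both gaps are beyond the usual scatter. Compound 4 `CS(=O)(=O)c1ccc2nc(NC(=O)NC(=O)c3ccccc3Cl)sc2c1` has not yet been measured. It differs from compound 2 in one place: hydrogen in place of 2-(4-methyl-1,4-diazepan-1-yl)ethyl on a saturated chain carbon bound to a sulfonyl sulfur. Going by the values given here, no measured pair shows this change directly, so its effect cannot be read off the data. Still, the expected step of a 7.1-fold higher number from compound 2 to compound 4 (0.85 log units; beyond the scatter) points toward a weaker inhibitor, a clearly higher number. Compound 4 is estimated at 30 nM, with a likely range from 5 nM to 200 nM.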

Compound 4, half-maximal inhibitory concentration: 120 nM
Compound 4: the middle estimate sits 4.0-fold (0.60 log units) below what was measured; measured number inside the range.
By their numbers in this assay, from the lowest: compounds 3 and 1 (each within the scatter of the next); then compound 2; then compound 4.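

In this assay, cutting the 3-(4-methyl-1,4-diazepan-1-yl)propyl group back to methyl on the sulfonyl sulfur gives a 29-fold higher number from compound 2 to compound 4 (1.46 log units; beyond the scatter), a large step. Going by these compounds alone, this is the first direct sign that the group on this sulfur matters strongly, since the earlier compounds differ from each other in more than one place. Nothing available here explains the rise. The compounds shown leave open whether the seven-membered ring is needed or a simpler amine would do. A propyl chain ending in dimethylamino, compared with one ending in hydroxyl, would begin to separate the contributions of chain and amine.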